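A few compounds are considered here, and "the series" means these few. Any claim that something is new, unique, unknown or untested is made for them only; others in the source may bear on it.

Measured so far:
Compound 1, `COc1ccc(NC(=O)Nc2cc(C)nc3ccccc23)cc1`, gives only a limit in an ADME assay on HepG2 cells (Homo sapiens) for cytotoxicity, with a stated time of 72 h (on this read-out lower numbers stand for an effect already at smaller amounts and higher numbers for an effect only at larger amounts of compound), namely > 25000 nM.
Compound 2, `COc1ccc(NC(=O)Nc2cc(C)nc3ccccc23)cc1F`, likewise gives only a limit in this assay, > 25000 nM.
Compound 3, `Cc1cc(NC(=O)Nc2ccc3[nH]cnc3c2)c2ccccc2n1`, also gives only a limit in this assay, > 25000 nM.

Compound 1 therefore stands at a limit of this assay rather than at a number, and so do the other two measured compounds: all three sit on the same line, (the limit of > 25000 nM in this assay, at which 3 of the 3 values shown sit). Among the compounds with values here, the one measured step that changes a single place, fluoro in place of hydrogen on an aromatic carbon, is a step that the two limits leave unreadable from compound 1 to compound 2, so its size cannot be read because both ends are limits.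

Compound 4, `Cc1cc(NC(=O)Nc2ccc(C(N)=O)cc2)c2ccccc2n1`, differs from compound 1 by carbamoyl in place of methoxy on an aromatic carbon.

Within the data shown here, no measured step bears on this change in a readable way, and none of the three measured compounds gives a number in this assay. Nothing here points toward a difference beyond the scatter, so compound 4 is expected to stay where compound 1 stands, at the limit of this assay. The step expected from compound 1 to compound 4 is a step that the limit leaves unreadable from compound 1 to compound 4, meaning no change that can be read. The estimate for compound 4 in this assay is therefore 30000 nM, with a range from 10000 nM to 100000 nM.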

Compound 4, half-maximal effective concentration: > 25000 nM
Compound 4: only a limit was reported; the forecaster's own chance of this, stated with the estimate: 85%; the middle value lies beyond the limit too.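

Within the data shown here, compound 4 gives only a limit, as compound 1 does, so the step between compound 1 and compound 4 cannot be read, and this result adds no new step. Still open is where any of these compounds would give an actual number in this assay, and whether carbamoyl in place of methoxy changes that number, as every value shown is a limit: the limit of > 25000 nM in this assay, at which 4 of the 4 values shown sit.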